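The compounds below may be only part of what the source reports. "The series", "measured", "known", "first", "only" and "open" are said of these compounds alone.

Series notes, aminoquinazoline thioacetamides bearing an acrylamide.

Compound 1 `C=CC(=O)Nc1cccc(NC(=O)CSc2nc(Nc3ccccc3Cl)c3ccccc3n2)c1`: in a functional assay on MDA-MB-231 cells (Homo sapiens) for inhibition, read by MTT assay, with a stated time of 72 h (on this read-out higher numbers stand for weaker inhibition and lower numbers for stronger inhibition), compound 1 gives 12700 nM.
Compound 2 `C=CC(=O)Nc1cccc(NC(=O)CSc2nc(Nc3ccccc3C)c3ccccc3n2)c1`: in this assay compound 2 gives 20400 nM.
Compound 3 `C=CC(=O)Nc1cccc(NC(=O)CSc2nc(Nc3cccc(Cl)c3)c3ccccc3n2)c1`: in this assay compound 3 gives 16300 nM.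

Compound 3 stands second highest of the three numbers, and neither of its steps, a 1.3-fold higher number from compound 1 to compound 3 (0.11 log units; within the scatter) nor a 1.3-fold lower number from compound 2 to compound 3 (0.10 log units; within the scatter), leaves the scatter. Compound 4 `C=CC(=O)Nc1cccc(NC(=O)CSc2nc(Nc3cccc(C)c3)c3ccccc3n2)c1` carries the change (methyl in place of chloro on an aromatic carbon). Within the data shown here, the one step that bears on it is the same swap at another position of that ring, a 1.6-fold higher number from compound 1 to compound 2 (0.21 log units; within the scatter), which stayed within the scatter. On that basis the step of a 1.2-fold higher number from compound 3 to compound 4 (0.09 log units; within the scatter) is expected to be small, with no change beyond the scatter, leaning if anything toward a higher number. Compound 4 is therefore estimated at 20000 nM, with a range of 10000 nM to 40000 nM.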

Compound 4, half-maximal inhibitory concentration: 16800 nM
Compound 4: middle estimate off by 1.2-fold (0.08 log units), on the high side; the range from low to high includes it.
By their numbers in this assay, from the lowest: compounds 1, 3, 4 and 2 (each within the scatter of the next).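

The swap of methyl for chloro now has two readings, and the new one, a 1.0-fold higher number from compound 3 to compound 4 (0.01 log units; within the scatter), agrees with the earlier one: the same change on two cores in this assay, a 1.6-fold higher number (0.21 log units; within the scatter) from compound 1 to compound 2 and a 1.0-fold higher number (0.01 log units; within the scatter) from compound 3 to compound 4, 1.6-fold (0.19 log units) apart, within the scatter of two such steps. Changing the aryl group on the nitrogen gives a 1.2-fold lower number from compound 2 to compound 4 (0.08 log units; within the scatter) and a 1.3-fold higher number from compound 1 to compound 4 (0.12 log units; within the scatter), so these four aryl groups read alike in this assay.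

Going by these compounds, whether the ring carbon meta to a large group accepts anything beyond chloro and methyl stays open, for example an amine or a carboxylic acid. On these data alone, the contribution of the acrylamide to these values also stays open.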